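A Methyl-to-Amino Swap on a Weak Sigma Ligand

This account rests on a few compounds, and the source may have more. Where it says the series, first, only, none or still open, it means among the compounds named here.

Measured so far:
Compound 1, `Cc1cccc(NC(=N)Nc2cccc3ccccc23)c1`: 75 nM
Compound 2, `Cc1cccc(N(C)C(=N)Nc2cccc3ccccc23)c1`: 1860 nM

Of the compounds shown here, two share a core and have been tested in an assay on membranes from brain (Cavia porcellus) for binding affinity to Sigma non-opioid intracellular receptor 1 (Homo sapiens), read by radioligand binding; on this read-out higher numbers stand for weaker inhibition and lower numbers for stronger inhibition. Compound 1 `Cc1cccc(NC(=N)Nc2cccc3ccccc23)c1` gives 75 nM, the lower of the two numbers. Among the measured compounds shown here, compound 2 `Cc1cccc(N(C)C(=N)Nc2cccc3ccccc23)c1` gives 1860 nM, and the single measured step, a 25-fold higher number from compound 1 to compound 2 (1.39 log units; beyond the scatter), is large. For the measured compounds named here, compound 2 therefore stands at the highest number so far, with compound 1 as its only neighbour, far below it.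

Compound 3 `CN(C(=N)Nc1cccc2ccccc12)c1cccc(N)c1` differs from compound 2 in one place: amino in place of methyl on an aromatic carbon. Going by the values given here, no measured step concerns a change on that ring; the one step known, a 25-fold higher number from compound 1 to compound 2 (1.39 log units; beyond the scatter), concerns a methyl on a nitrogen and says nothing about replacing a methyl by an amino group on the aromatic carbon. With no direct guide, the expectation in this assay is a step of modest size, with wide uncertainty in either direction. Compound 3 is estimated at 2500 nM, with a range from 600 nM to 10000 nM, which corresponds to an expected step of a 1.3-fold higher number from compound 2 to compound 3 (0.13 log units; within the scatter).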

Compound 3, half-maximal inhibitory concentration: 2700 nM
The estimate for compound 3 lay 1.1-fold (0.03 log units) below the measured number; the measured number falls inside the stated range.
By their numbers in this assay, from the lowest: compound 1; then compounds 2 and 3 (each within the scatter of the next).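

In this assay, the change from 3-methylphenyl to 3-aminophenyl comes with a 1.5-fold higher number from compound 2 to compound 3 (0.16 log units; within the scatter), so the two numbers cannot be told apart. Among the compounds shown here, this is the first view of a change on this ring, since the earlier step, a 25-fold higher number from compound 1 to compound 2 (1.39 log units; beyond the scatter), concerned a methyl on a nitrogen. Here, a methyl on an aromatic carbon gives way to an amino group, which brings one hydrogen-bond donor and one hydrogen-bond acceptor, yet the read-out shows no change beyond the scatter, at least with the methyl on the nitrogen present in both compound 2 and compound 3. Nothing available explains why this swap leaves the number within the scatter.

The compounds shown leave open whether the same swap would also pass within the scatter on compound 1, which carries a hydrogen instead of that methyl on the nitrogen. They also leave open whether a larger or differently built group at this place, such as a methoxy group, a chlorine atom or a carboxylic acid, would move the number, and in which direction.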